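Spiro amine substituent swap: methylsulfonyl to carbamoylmethyl

The source may report more compounds than this note shows. Statements on the series, on what has been measured and on what is new or still open speak of the compounds shown alone.

The series shares one core; compound 1 is `Cc1cc(C)cc(S(=O)(=O)c2c(C(=O)NC3CC4(C3)CN(C(=O)OC(C)(C)C)C4)[nH]c3ccc(Cl)cc23)c1`, compound 2 is `Cc1cc(C)cc(S(=O)(=O)c2c(C(=O)NC3CC4(CCN(S(C)(=O)=O)CC4)C3)[nH]c3ccc(Cl)cc23)c1`, compound 3 is `Cc1cc(C)cc(S(=O)(=O)c2c(C(=O)NC3CC4(C3)CN(CC(N)=O)C4)[nH]c3ccc(Cl)cc23)c1` and the unmeasured compound 4 is `Cc1cc(C)cc(S(=O)(=O)c2c(C(=O)NC3CC4(CCN(CC(N)=O)CC4)C3)[nH]c3ccc(Cl)cc23)c1`.

In a toxicity assay on MT4 cells (Homo sapiens) for cytotoxicity, read by MTT assay, with a stated time of 7 days (on this read-out higher numbers stand for lower toxicity in this test and lower numbers for higher toxicity in this test), compound 2 reports only a limit, > 221000 nM. Compound 1 likewise reports only a limit in this assay, > 224000 nM. Compound 3 gives a number in this assay, 6080 nM. Among the compounds with values here, compound 2 thus stands at one of the two limits, (the limit of > 221000 nM in this assay, at which 1 of the 3 values shown sits), compound 1 sits at the other, (the limit of > 224000 nM in this assay, at which 1 of the 3 values shown sits), and compound 3 is the one compound with a measured value.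

Compound 4 differs from compound 2 by carbamoylmethyl in place of methylsulfonyl on an amine nitrogen in a ring. Within the data shown here, the one measured step that bears on this change is an at least 36-fold lower number from compound 1 to compound 3 (1.56 log units; beyond the scatter), where the same carbamoylmethyl group entered in place of tert-butoxycarbonyl on an amine nitrogen in a ring. In compound 4 the entering group is the same and the leaving group is methylsulfonyl, so a step of the same kind is expected, a large move to a lower number in this assay, estimated as an at least 27-fold lower number from compound 2 to compound 4 (1.44 log units; beyond the scatter). Compound 4 is therefore expected to give about 8000 nM in this assay, within a range of 2000 nM to 60000 nM.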

Compound 4, half-maximal cytotoxic concentration: 3610 nM
For compound 4 the middle estimate is 2.2-fold (0.35 log units) above the measured one, within the range that was stated.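

In this assay, carbamoylmethyl in place of methylsulfonyl on an amine nitrogen in a ring gives an at least 61-fold lower number from compound 2 to compound 4 (1.78 log units; beyond the scatter), so the large move no longer rests on a single pair, an at least 36-fold lower number from compound 1 to compound 3 (1.56 log units; beyond the scatter). The move to higher toxicity in this test now appears with two different leaving groups, tert-butoxycarbonyl and methylsulfonyl, and with carbamoylmethyl on two different ring systems, here a six-membered non-aromatic ring with 1 nitrogen, joined to another ring at one shared atom. Compound 2 stands at a limit of the assay, so the step from it fixes only a minimum size and the full size stays unknown: the limit of > 221000 nM in this assay, at which 1 of the 4 values shown sits.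

Going by these compounds, whether the lower number belongs to carbamoylmethyl in particular or would follow other groups on this nitrogen stays open; a carboxymethyl group, an aminoethyl chain or a longer chain ending in the same amide would separate these readings. The compounds shown tie the step to no measured property, so its cause also remains open.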